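The compounds below may be only part of what the source reports. "The series", "measured", "known", "first", "only" and "open" are said of these compounds alone.

Compound 1 `Cc1nc(C(F)(F)F)ccc1C(=O)Nc1ccc(Cl)c(-c2cc3ccccc3[nH]2)c1` carries the shared core with a 1H-indol-2-yl group on the aromatic carbon. Within the data shown here, in an assay on C3H 10T1/2 cells for inhibition of Sonic hedgehog protein (Mus musculus), read by a luciferase reporter (a higher number here means a weaker inhibitor, a lower number a stronger inhibitor), compound 1 gives 500 nM, the highest of the three numbers so far. Compound 2 `Cc1nc(C(F)(F)F)ccc1C(=O)Nc1ccc(Cl)c(-n2cc3ccccc3n2)c1` gives 80 nM in this assay, and compound 3 `Cc1nc(C(F)(F)F)ccc1C(=O)Nc1ccc(Cl)c(-n2cccn2)c1` gives 450 nM. The step of a 6.3-fold lower number from compound 1 to compound 2 (0.80 log units; beyond the scatter) is beyond the scatter, whereas a 1.1-fold lower number from compound 1 to compound 3 (0.05 log units; within the scatter) stays within it; between the two substituted rings, a 5.6-fold higher number from compound 2 to compound 3 (0.75 log units; beyond the scatter) completes the picture.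

Compound 4 `Cc1nc(C(F)(F)F)ccc1C(=O)Nc1ccc(Cl)c(-c2ccn(C)n2)c1` is not yet measured. Against compound 1 the change is 1-methyl-1H-pyrazol-3-yl in place of 1H-indol-2-yl on an aromatic carbon. Among the measured compounds shown here, the step that bears most closely on it is the one to compound 3, where a five-membered ring with two hetero atoms also took the place of the 1H-indol-2-yl group and the number did not move beyond the scatter. The gain seen in compound 2 came with the 2H-indazol-2-yl group, which compound 4 does not carry, so it is not taken as a guide here.

For the measured compounds named here, compound 4 is therefore expected to show a step of a 1.3-fold lower number from compound 1 to compound 4 (0.10 log units; within the scatter), no larger than the scatter, because a 1.1-fold lower number from compound 1 to compound 3 (0.05 log units; within the scatter) is the nearest precedent. The estimate for compound 4 in this assay is 400 nM, with a range from 150 nM to 1200 nM.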

Compound 4, half-maximal inhibitory concentration: 550 nM
Compound 4: the middle estimate sits 1.4-fold (0.14 log units) below what was measured; the measured number falls inside the stated range.
By their numbers in this assay, from the lowest: compound 2; then compounds 3, 1 and 4 (each within the scatter of the next).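

In this assay, the step of a 1.1-fold higher number from compound 1 to compound 4 (0.04 log units; within the scatter) shows that, on this aromatic carbon ortho to the chloro group, the 1H-indol-2-yl group can give way to a 1-methyl-1H-pyrazol-3-yl group with no shift beyond the scatter, even though the incoming group has no hydrogen-bond donor and no six-membered aromatic ring. Among these compounds, the step of a 1.2-fold higher number from compound 3 to compound 4 (0.09 log units; within the scatter) adds that the 1-methyl-1H-pyrazol-3-yl and 1H-pyrazol-1-yl groups, which differ in the methyl group and in the ring atom carrying the bond, cannot be told apart here, while a 6.9-fold higher number from compound 2 to compound 4 (0.84 log units; beyond the scatter) leaves compound 2 as the only member of the series set apart from the others beyond the scatter. No measurement on hand accounts for any of these steps.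

Still open, on these data alone, is whether the lower number of compound 2 depends on the fused ring itself or on its attachment through ring nitrogen, and the two pyrazole compounds cannot separate the methyl group from the change of attachment. As far as these compounds go, how this position would respond to a non-aromatic group such as a morpholine ring, an amine or a carboxylic acid also remains unknown from these compounds.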